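This account rests on a few compounds, and the source may have more. Where it says the series, first, only, none or still open, it means among the compounds named here.

Compound 1, `Cc1ccccc1S(=O)(=O)Nc1ccc2oc(-c3ccccc3)nc2c1`, gives 57000 nM in an ADME assay on HEK293 cells (Homo sapiens) for cytotoxicity, read by resazurin assay, with a stated time of 48 h; a lower number here means that less compound is tolerated, a higher number that more compound is tolerated. Compound 2, `O=S(=O)(Nc1ccc2oc(-c3ccccc3)nc2c1)c1ccc(Cl)cc1`, gives 65000 nM in this assay. Compound 3, `O=[N+]([O-])c1cc(S(=O)(=O)Nc2ccc(-c3nc4ccccc4o3)cc2)ccc1Cl`, gives 85000 nM in this assay.

Compound 3 carries the highest of the three numbers, yet its distance to compound 2 and to compound 1 both lie within the scatter, so it cannot be set apart from them. The new compound is compound 4, `O=S(=O)(Nc1ccc(-c2nc3ccccc3o2)cc1)c1ccc(Cl)cc1`. It differs from compound 3 by hydrogen in place of nitro on an aromatic carbon.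

Within the data shown here, only one measured step exists, a 1.1-fold higher number from compound 1 to compound 2 (0.06 log units; within the scatter), and it concerns the group on the sulfonyl sulfur rather than a nitro group; it stayed within the scatter. Among the measured compounds shown here, no measured step removes a nitro group, so the change is untested here. Given that the one known change left this assay unmoved, and given that compound 2, which shares the 4-chlorophenyl group, gives 65000 nM, the step of a 1.1-fold lower number from compound 3 to compound 4 (0.05 log units; within the scatter) is expected to stay within the scatter. Compound 4 is therefore estimated at 75000 nM, with a range from 40000 nM to 150000 nM.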

Compound 4, half-maximal cytotoxic concentration: > 100000 nM
Compound 4 was reported as a limit (the forecaster's own chance of this, stated with the estimate: 20%); middle value at least 1.3-fold (0.12 log units) from the limit.
By their numbers in this assay, from the lowest: compounds 1, 2 and 3 (each within the scatter of the next). At a limit, above all of these: compound 4.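

Compound 4 gives > 100000 nM in this assay, which is a limit of the assay and not a number. Hydrogen in place of nitro on this aromatic carbon, ortho to a chloro group, gives an at least 1.1-fold higher number from compound 3 to compound 4 (0.07 log units; that floor lies within the scatter), so this is the first step shown at this position, and only its floor is known. That floor does not establish a rise, but it shows that the nitro group is not needed here for a high number, and the true size of the step stays hidden at the limit: the limit of > 100000 nM in this assay, at which 1 of the 4 values shown sits.

The compounds shown leave open whether an amine or a carboxylic acid on this same carbon would keep the number at this level. Also open, going by these compounds, is whether the same change would behave alike with 2-methylphenyl on the sulfonyl sulfur.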